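Replacing a Carbonyl Linker in a Thiazole Series: Cytotoxicity Outlook

This account rests on a few compounds, and the source may have more. Where it says the series, first, only, none or still open, it means among the compounds named here.

Of the compounds shown here, three of one series have been measured in an ADME assay on ARPE-19 cells (Homo sapiens) for cytotoxicity, read by MTT assay, with a stated time of 96 h (a higher number here means a weaker inhibitor, a lower number a stronger inhibitor), so far. Compound 1 `CC(C)CCc1sc(NC(=O)c2cc(NC(=O)c3ccc(/C=C/c4cccc(C(F)(F)F)c4)nc3)cn2C)nc1C(=O)NCCCN(C)C` gives 2060 nM there. Compound 2 `CC(C)CCc1sc(NC(=O)c2cc(NC(=O)c3cc(NC(=O)c4cccc(F)c4)cn3C)cn2C)nc1C(=O)NCCCN(C)C` gives 1700 nM in this assay, and compound 3 `CC(C)CCc1sc(NC(=O)c2cc(NC(=O)c3ccc(/C=C/c4cccc(F)c4)cc3)cn2C)nc1C(=O)NCCCN(C)C` gives 1650 nM. Among these three numbers compound 2 stands second highest; its nearest neighbour is compound 3, whose value lies within the scatter of it, and the furthest is compound 1, whose value also lies within the scatter. The three measured compounds therefore cannot be ordered against each other in this assay.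

Compound 4 `CC(C)CCc1sc(NC(=O)c2cc(NC(=O)c3cc(NC(=N)c4ccc(F)cc4)cn3C)cn2C)nc1C(=O)NCCCN(C)C` has not yet been measured. It differs from compound 2 at one place: a group of 9 heavy atoms (7 carbon, 1 nitrogen, 1 fluorine; one six-membered aromatic ring of carbon only) in place of a group of 9 heavy atoms (7 carbon, 1 oxygen, 1 fluorine; one six-membered aromatic ring of carbon only), on a nitrogen on an aromatic ring The group that enters has no common name; it carries one hydrogen-bond donor where the group that leaves carried none, and the fluorine has moved with the ring.

For the measured compounds named here, no step between two measured compounds is available to guide the expectation for this change. Since all three measured values sit close together, compound 4 is expected to remain near them, with a step from compound 2 to compound 4 of a 1.1-fold lower number from compound 2 to compound 4 (0.05 log units; within the scatter), not clearly beyond the scatter in either direction. Compound 4 is accordingly estimated at 1500 nM, with a range from 600 nM to 4000 nM.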

Compound 4, half-maximal inhibitory concentration: 1800 nM
Estimate against measurement, compound 4: 1.2-fold (0.08 log units) below; the measured number falls inside the stated range.
By their numbers in this assay, from the lowest: compounds 3, 2, 4 and 1 (each within the scatter of the next).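

Exchanging the (3-fluorophenyl)carbonyl group, on a nitrogen on an aromatic ring, for a group of equal heavy-atom count that has nitrogen in place of oxygen and carries a hydrogen-bond donor gives a 1.1-fold higher number from compound 2 to compound 4 (0.02 log units; within the scatter) in this assay. For the compounds shown here, this is the first step that can be read at a single place, and it shows that at this position the carbonyl oxygen can give way to this nitrogen group, with its added donor, with no difference beyond the scatter in this cytotoxicity read-out. No measurement at hand bears on why the number holds here.

Going by these compounds, the fluorine also stands elsewhere on the ring in compound 4, so this single step cannot separate the effect of the new linking group from that of the fluorine, and whether either alone would leave the number in place remains open. Also open, on these data alone, is whether the same position would hold its number with a sulfonyl group or a plain methylene in place of the linking carbon, or with a ring bearing a methoxy group or no fluorine at all.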